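Dichloroacetanilide series: methoxy to (trifluoromethyl)sulfanyl step

The source may report more compounds than this note shows. Statements on the series, on what has been measured and on what is new or still open speak of the compounds shown alone.

The shared core is the dichloroacetamide of an aniline, seen in compound 1 `Cc1cccc(NC(=O)C(Cl)Cl)c1`, for which a functional assay on BGC-823 cells (Homo sapiens) for antiproliferative activity, read by MTT assay, with a stated time of 72 h (a higher number here means a weaker inhibitor, a lower number a stronger inhibitor), reports "not determined" (no result reported), and in compound 2 `O=C(Nc1cccc(F)c1)C(Cl)Cl`, for which this assay reports "not determined" (no result reported). Compound 3 `COc1cccc(NC(=O)C(Cl)Cl)c1` is the only entry with a result: in this assay compound 3 gives 179000 nM, a weak inhibitor, and with no second number there is nothing within the series to rank it against. Compound 4 `O=C(Nc1cccc(SC(F)(F)F)c1)C(Cl)Cl` differs from compound 3 by (trifluoromethyl)sulfanyl in place of methoxy on an aromatic carbon. Among the compounds with values here, no step between two measured compounds exists to size this change from, so the expectation rests on compound 3 alone. The step from compound 3 to compound 4 is expected to be a 1.8-fold lower number from compound 3 to compound 4 (0.25 log units; within the scatter), a modest move toward stronger inhibition that may not exceed the scatter. Compound 4 is estimated at 100000 nM, within a range from 30000 nM to 300000 nM.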

Compound 4, half-maximal inhibitory concentration: 123000 nM
Compound 4: the middle estimate sits 1.2-fold (0.09 log units) below what was measured; the measured number falls inside the stated range.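

In this assay, (trifluoromethyl)sulfanyl in place of methoxy on an aromatic carbon gives a 1.5-fold lower number from compound 3 to compound 4 (0.16 log units; within the scatter) and so leaves the two compounds indistinguishable. This position therefore accepts a group of 5 heavy atoms in place of one of 2 without a change that can be read. No supporting data bear on why this is so.

Steps involving compound 1 and compound 2 cannot be read, as neither has a result. From the compounds shown here alone, how an amine, a carboxylic acid or a longer alkoxy chain would behave at this position remains open.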